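Shortening the chain of compound 2: a cytotoxicity estimate

The source may report more compounds than this note shows. Statements on the series, on what has been measured and on what is new or still open speak of the compounds shown alone.

Compound 1 `CCCCCCC[C@@H]1CC(O)=C(C(=O)CCC)C(=O)O1`: "not determined" (no result reported)
Compound 2 `CCCCCCCCC[C@@H]1CC(O)=C(C(=O)CCC)C(=O)O1`: 33 ug/mL

In an ADME assay on HepG2 cells (Homo sapiens) for cytotoxicity, read by XTT assay, with a stated time of 48 h (on this read-out lower numbers stand for higher toxicity in this test and higher numbers for lower toxicity in this test), compound 2 gives 33 ug/mL. For the measured compounds named here, this is the only number available, so compound 2 cannot be ranked against anything, and no measured step shows how the chain affects the read-out. Compound 3 `CCCC(=O)C1=C(O)C[C@@H](CC)OC1=O` keeps the shared core and has yet to be tested. Its difference from compound 2 is hydrogen in place of heptyl on a saturated chain carbon, two bonds along the chain from a saturated ring carbon, on a saturated chain carbon, two bonds along the chain from a saturated ring carbon. With only the value of compound 2 at 33 ug/mL and this structural change to go on, a moderate rise beyond the usual scatter is expected in this assay, pointing to lower toxicity in this test. The estimated change is a 2.7-fold higher number from compound 2 to compound 3 (0.44 log units; beyond the scatter). Compound 3 is expected at 90 ug/mL, with an estimated range of 35 ug/mL to 250 ug/mL.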

Compound 3, half-maximal cytotoxic concentration: > 100 ug/mL
Compound 3 was reported as a limit (the forecaster's own chance of this, stated with the estimate: 30%); middle value at least 1.1-fold (0.04 log units) away from the limit.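

Hydrogen in place of heptyl on a saturated chain carbon, two bonds along the chain from a saturated ring carbon, gives the first measured step at this position: an at least 3.0-fold higher number from compound 2 to compound 3 (0.48 log units; beyond the scatter) in this assay. For the compounds shown here, removing heptyl here therefore goes with lower toxicity in this test, a direction that the single value of compound 2 could not show. Only a lower bound on the size of the change can be read, as the result for compound 3 is a limit and not a number: the limit of > 100 ug/mL in this assay, at which 1 of the 3 values shown sits.

The compounds shown leave open whether the read-out moves gradually with the length of the chain at this place, as a single step gives no trend. They also leave open how an amine or a carboxylic acid in place of heptyl would read in this assay.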